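Chloro to Fluoro: Expecting the Cytotoxicity of Compound 4

This account rests on a few compounds, and the source may have more. Where it says the series, first, only, none or still open, it means among the compounds named here.

Of the compounds shown here, three sharing one core have been tested in a functional assay on A549 cells (Homo sapiens) for cytotoxicity, read by sulforhodamine B assay, with a stated time of 2 days, tested at 100 uM; a higher number here means more inhibition at the concentration tested (going by the name of the read-out), a lower number less inhibition. Compound 1 `CCCc1n[nH]c2c(=O)n(NC(=O)c3ccncc3)c(-c3cccc(OC)c3)nc12` gives 11.2%. Compound 3 `COc1cccc(-c2nc3c(-c4ccc(Cl)cc4)n[nH]c3c(=O)n2NC(=O)c2ccncc2)c1` carries a 4-chlorophenyl where compound 1 carries a propyl; compound 3 gives 46%; the step between them is a number 34.8 percentage points higher from compound 1 to compound 3 (beyond the scatter). Among the compounds with values here, compound 2 `O=C(Nn1c(-c2cccc([N+](=O)[O-])c2)nc2c(-c3ccc(Cl)cc3)n[nH]c2c1=O)c1cccnc1` gives 19.7%; this number lies within the usual scatter of compound 1 and well below compound 3, the only measured compound clearly apart from it.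

Compound 4 `O=C(Nn1c(-c2cccc([N+](=O)[O-])c2)nc2c(-c3ccc(F)cc3)n[nH]c2c1=O)c1cccnc1` differs from compound 2 by fluoro in place of chloro on an aromatic carbon. Within the data shown here, only one step has been measured, and it concerns exchanging a propyl for the whole 4-chlorophenyl, not the halogen on that ring; no measured pair shows what replacing chloro with fluoro does here. Both compound 2 and compound 3 carry the 4-chlorophenyl, yet their numbers differ widely, so that group alone does not fix the outcome. Without direct guidance, the expected step is a number 3.7 percentage points lower from compound 2 to compound 4 (within the scatter), which means nothing beyond the scatter. Compound 4 is therefore expected to give 16%, with a range from 3% to 32%.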

Compound 4, a percentage reported as inhibition, at one concentration (the size of the read-out at that concentration, not a potency): 28.8%
For compound 4 the middle estimate is 12.8 percentage points below the measured one, within the range that was stated.
By their numbers in this assay, from the lowest: compounds 1, 2 and 4 (each within the scatter of the next, the first and the last beyond it); then compound 3.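

Within the data shown here, putting fluoro in place of chloro, para to a large group on the six-membered ring, gives a number 9.1 percentage points higher from compound 2 to compound 4 (within the scatter) in this assay and so provides the first direct measurement of a change to the halogen itself. The earlier step replaced a propyl with the whole 4-chlorophenyl, whereas this one keeps the ring and shows that, for this pair, exchanging one halogen for the other does not move the number beyond what repeat measurements could produce. No measured evidence bears on this result, so it offers no explanation for the size of the step.

Going by these compounds, it remains open whether an amine or a carboxylic acid in this same position would separate clearly from compound 2. Also unknown is whether the same halogen exchange would give a similar step on compound 3, which differs elsewhere.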